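Fluorine Added to the Benzamide of Compound 2

A few compounds are considered here, and "the series" means these few. Any claim that something is new, unique, unknown or untested is made for them only; others in the source may bear on it.

Measured so far in a functional assay on SNB-75 cells (Homo sapiens) for antiproliferative activity; a lower number here means a stronger inhibitor of growth, a higher number a weaker inhibitor of growth:
compound 1, `COc1cccc(-c2nn(-c3ccccc3)cc2-c2ccnc(NCCCNC(=O)Nc3ccc(Cl)c(Cl)c3)c2)c1`: 2520 nM
compound 2, `O=C(NCCCNc1cc(-c2cn(-c3ccccc3)nc2-c2cccc(O)c2)ccn1)c1ccccc1`: 1680 nM

Compound 2 holds the lower of the two numbers, but its gap to compound 1 lies within the usual scatter of repeated measurements, so the two cannot be told apart on this evidence. Compound 3, `O=C(NCCCNc1cc(-c2cn(-c3ccccc3)nc2-c2cccc(O)c2)ccn1)c1ccc(F)cc1`, differs from compound 2 by fluoro in place of hydrogen on an aromatic carbon; the same difference, read one bond further out, is benzamido to ((4-fluorophenyl)carbonyl)amino. Among the measured compounds shown here, no pair of measured compounds shows this kind of change, so there is no measured step to lean on. In the absence of such a step, the expected step in this assay from compound 2 to compound 3 is small, with no clear direction and probably not beyond the scatter. Compound 3 is therefore estimated at 1500 nM, within a range of 600 nM to 4000 nM, which corresponds to an expected step of a 1.1-fold lower number from compound 2 to compound 3 (0.05 log units; within the scatter).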

Compound 3, concentration for 50% growth inhibition: 5190 nM
Beside the measured number, compound 3's estimate is 3.5-fold (0.54 log units) below it, outside the stated range (above it).
By their numbers in this assay, from the lowest: compounds 2 and 1 (each within the scatter of the next); then compound 3.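

In this assay, fluoro in place of hydrogen on the benzamide ring gives a 3.1-fold higher number from compound 2 to compound 3 (0.49 log units; beyond the scatter), the only measured change at this ring among the compounds shown. A single heavy atom, placed on an aromatic carbon para to a large group, is thus enough to move the number beyond the scatter, and it moves towards weaker inhibition of growth, so this place does not tolerate every change without effect. Nothing measured here offers an explanation for this step.

As far as these compounds go, it remains open whether the step is particular to fluoro or would also follow a nitrile, an amine or a carboxylic acid on the same carbon. From the compounds shown here alone, it is also open whether the other carbons of this ring respond in the same way.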